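The compounds below may be only part of what the source reports. "The series", "measured", "known", "first", "only" and "open" are said of these compounds alone.

Measured compounds:
compound 1 `O=C(NN1CCOCC1)c1c(O)c2cccnc2n(-c2ccccc2)c1=O` — -26.2% in a functional assay on the whole organism for inhibition, with Rattus norvegicus as the target, read by cytopathic effect and paw edema, at a dose of 100 mg/kg by the oral route; a lower number here means less inhibition, a higher number more inhibition at the dose given (going by the name of the read-out)
compound 2 `O=C(Nc1ccccc1)c1c(O)c2cccnc2n(-c2ccccc2)c1=O` — -15%
compound 3 `O=C(Nc1ccc([N+](=O)[O-])cc1)c1c(O)c2cccnc2n(-c2ccccc2)c1=O` — -25.8%

Among these three, compound 1 gives the lowest number, with compound 3 close by and compound 2 highest. Compound 4 `O=C(Nc1cccc([N+](=O)[O-])c1)c1c(O)c2cccnc2n(-c2ccccc2)c1=O` is not yet measured. Its change from compound 1 is 3-nitrophenyl in place of morpholin-4-yl on an amide-type nitrogen.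

Among the measured compounds shown here, two measured steps bear on this. Putting phenyl in place of morpholin-4-yl gave a number 11.2 percentage points higher from compound 1 to compound 2 (beyond the scatter). Putting 4-nitrophenyl in place of morpholin-4-yl gave a number 0.4 percentage points higher from compound 1 to compound 3 (within the scatter). A nitro on the phenyl thus removed the gain, as a number 10.8 percentage points lower from compound 2 to compound 3 (beyond the scatter) shows. Compound 4 carries its nitro elsewhere on the phenyl, so a step between those two, near the scatter edge, is expected: a number 6.2 percentage points higher from compound 1 to compound 4 (within the scatter). Compound 4 is estimated at -20%, within -32% to -8%.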

Compound 4, a percentage reported as inhibition, in the whole organism at one dose (the size of the read-out at that dose, not a potency): 7.4%
Compound 4: middle estimate off by 27.4 percentage points, on the low side; the whole stated range lies below it.
By their numbers in this assay, from the lowest: compounds 1 and 3 (each within the scatter of the next); then compound 2; then compound 4.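

In this assay, the place of the nitro on the phenyl matters: 3-nitrophenyl in place of 4-nitrophenyl gives a number 33.2 percentage points higher from compound 3 to compound 4 (beyond the scatter) and so shows that these two groups cannot be treated as one change. Adding a nitro to the phenyl is therefore not always a loss, as a number 22.4 percentage points higher from compound 2 to compound 4 (beyond the scatter) and a number 33.6 percentage points higher from compound 1 to compound 4 (beyond the scatter) both point the other way from the earlier nitro step. No measurement here explains the difference between the two nitrophenyl groups. The compounds shown leave open whether an amine or a carboxylic acid on the phenyl would behave like the nitro of compound 4 or that of compound 3.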